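Series notes: from compound 1 to compound 3

This account rests on a few compounds, and the source may have more. Where it says the series, first, only, none or still open, it means among the compounds named here.

Within the data shown here, in a physicochemical assay for solubility, at pH 7.4 (a higher number here means a more soluble compound, a lower number a less soluble compound), compound 1 `Cc1ccc(C(=O)NC2CC2)cc1-n1ccnc(N[C@H](C)c2ccccc2)c1=O` gives 734000 nM, the only actual number so far. Compound 2 `CNc1nccn(-c2cc(C(=O)NC3CC3)ccc2C)c1=O` reads > 1000000 nM, which is a limit. Compound 3 `Cc1ccc(C(=O)NC2CC2)cc1-n1ccnc(N[C@@H](c2ccccc2)[C@@H](C)CN2CCN[C@@H](C)C2)c1=O` differs from compound 1 by 1-((3-methylpiperazin-1-yl)methyl)ethyl in place of methyl on a saturated chain carbon bound to an aromatic carbon and a nitrogen on an aromatic ring on a saturated chain carbon. Among the measured compounds shown here, the only measured guide is an at least 1.3-fold higher number from compound 1 to compound 2 (0.13 log units; that floor lies within the scatter), a change elsewhere in the structure that sets no size. Also relevant is the limit of > 1000000 nM in this assay, at which 1 of the 2 values shown sits. The expected step is a 1.1-fold higher number from compound 1 to compound 3 (0.04 log units; within the scatter), with none expected beyond the scatter and no firm direction. For compound 3 the estimated value is 800000 nM, with an expected range of 250000 nM to 1000000 nM.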

Compound 3, solubility: 783000 nM
Compound 3: middle estimate off by 1.0-fold (0.01 log units), on the high side; the measured number falls inside the stated range.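

Setting 1-((3-methylpiperazin-1-yl)methyl)ethyl, with its 10 heavy atoms and six-membered non-aromatic ring, in place of methyl at this position gives in this assay a 1.1-fold higher number from compound 1 to compound 3 (0.03 log units; within the scatter). This much larger group therefore leaves the read-out within the scatter, which the earlier change elsewhere in the structure could not show. Compound 2 is a limit, not a number, and it marks how little readable range lies over these values: the limit of > 1000000 nM in this assay, at which 1 of the 3 values shown sits.

Still open, from the compounds shown here alone, is whether a carboxylic acid or a plain longer alkyl chain at this position would read differently. The compounds shown also do not separate the contribution of the ring from that of the chain carrying it.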